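Adding a second methoxy to the aminophenyl chalcone pyrazole

The source may report more compounds than this note shows. Statements on the series, on what has been measured and on what is new or still open speak of the compounds shown alone.

Compound 1, `COc1ccc(-c2cc(/C=C/C(=O)c3ccc(N)cc3)[nH]n2)cc1`, is the weakest of the three compounds measured in a functional assay on K562 cells (Homo sapiens) for cytotoxicity, read by sulforhodamine B assay, with a stated time of 48 h, tested at 1 uM (a lower number here means a stronger effect, a higher number a weaker effect of the compound at the concentration tested), where compound 1 gives 58%. Compound 2, `COc1ccc(C(=O)/C=C/c2cc(-c3cc(OC)c(OC)c(OC)c3)n[nH]2)cc1OC`, gives 75%, and compound 3, `COc1ccc(C(=O)/C=C/c2cc(-c3cc(OC)c(OC)c(OC)c3)n[nH]2)cc1`, gives 89%. Compound 4, `COc1ccc(-c2cc(/C=C/C(=O)c3ccc(N)cc3)[nH]n2)cc1OC`, differs from compound 1 in one place: methoxy in place of hydrogen on an aromatic carbon. For the measured compounds named here, the only measured step that speaks to this change runs the other way, hydrogen in place of methoxy, and it was a number 14 percentage points higher from compound 2 to compound 3 (beyond the scatter). Read backwards, putting methoxy in place of hydrogen lowered the number there, though on a differently arranged core. A modest fall beyond the scatter is therefore expected, a number 11 percentage points lower from compound 1 to compound 4 (beyond the scatter), giving compound 4 an estimated 47% with a range from 34% to 62%.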

Compound 4, a percentage reported as activity, at one concentration (the size of the read-out at that concentration, not a potency): 71%
Compound 4: the middle estimate sits 24 percentage points below what was measured; measured number above the stated range.
By their numbers in this assay, from the lowest: compound 1; then compounds 4 and 2 (each within the scatter of the next); then compound 3.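

On the core of compound 1, methoxy in place of hydrogen, ortho to a methoxy group, gives a number 13 percentage points higher from compound 1 to compound 4 (beyond the scatter), which means a weaker effect at the concentration tested. The earlier step pointed the opposite way, so this exchange has no single direction across the two cores: the same change on two cores in this assay, a number 14 percentage points higher (beyond the scatter) from compound 2 to compound 3 and a number 13 percentage points lower (beyond the scatter) from compound 4 to compound 1, 27 percentage points apart, beyond the scatter of two such steps.

As far as these compounds go, whether a hydroxy group, a fluorine or an ethoxy group on this same aromatic carbon would also weaken the effect remains open. So does the effect of the same methoxy elsewhere on this ring.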